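The compounds below may be only part of what the source reports. "The series", "measured", "known", "first", "only" and "open" are said of these compounds alone.

Working notes on the series. Three compounds have been run so far: compound 1 `COc1ccccc1NC(=O)c1ccnc2cc(Br)ccc12`, compound 2 `O=C(Nc1cccc(C(F)(F)F)c1)c1cc(=O)[nH]c2cc(Br)ccc12` and compound 3 `O=C(Nc1cccc(F)c1)c1cc(=O)[nH]c2cc(-c3ccccc3)ccc12`. In a functional assay on KYSE-70 cells for antiproliferative activity against KYSE-70 cell line (Homo sapiens), read by MTT assay, with a stated time of 72 h (a lower number here means a stronger inhibitor, a higher number a weaker inhibitor), compound 1 gives > 20000 nM, which is a limit of the assay and not a number. Compound 2 gives > 20000 nM in this assay, again a limit. Compound 3 stands at > 20000 nM in this assay, likewise a limit. Taken together, (the limit of > 20000 nM in this assay, at which 3 of the 3 values shown sit), so no step between any two measured compounds can be computed and no direction of change can be read from the numbers.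

The next compound to be measured is compound 4 `O=C(Nc1cccc(F)c1)c1cc(=O)[nH]c2cc(C3CC3)ccc12`. Compared with compound 3 it carries the change (cyclopropyl in place of phenyl on an aromatic carbon). Within the data shown here, with all three known values sitting at the same limit, there is no measured step that points either way for this kind of change, and the expectation is a step from compound 3 to compound 4 of a number no higher from compound 3 to compound 4 (the limit leaves the size open), that is, none beyond the scatter. Compound 4 is accordingly expected to give about 20000 nM in this assay, within a range from 6000 nM to 60000 nM, most likely reported as a limit again.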

Compound 4, half-maximal inhibitory concentration: > 20000 nM
Compound 4: no number, only a limit; the forecaster's own chance of this, stated with the estimate: 80%; the middle value lies on the limit itself.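

No step can be read from compound 3 to compound 4, since the values of both in this assay are limits of the assay and not numbers: the limit of > 20000 nM in this assay, at which 4 of the 4 values shown sit.

The compounds shown leave open how cyclopropyl and phenyl compare on that aromatic carbon, and which structural change, if any, would give a measurable value in this assay.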